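Side-chain variation on the shared core: working notes

The source may hold more compounds than are shown below. What is called first, only, known or untested is meant among the compounds shown, and "the series" means these compounds.

Measured compounds:
- compound 1, `CSCC[C@H](NC(=O)CN(c1nc(Cl)nc2[nH]cnc12)C1CC1)C(=O)OCc1ccccc1`, in a functional assay on the whole organism (Tail, strain ICR) with Mus musculus as the target, in the tail flick test, with a stated time of 90 min, at a dose of 25 umol/kg by the oral route (a higher number here means a stronger effect of the compound at the dose given, a lower number a weaker effect), compound 1 gives 44.6%
- compound 2, `O=C(O)CC[C@H](NC(=O)CN(c1nc(Cl)nc2[nH]cnc12)C1CC1)C(=O)O`, in this assay compound 2 gives 44.7%
- compound 3, `C[C@H](NC(=O)CN(c1nc(Cl)nc2[nH]cnc12)C1CC1)C(=O)OCc1ccccc1`, in this assay compound 3 gives 44.2%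

Compound 2 holds the highest of the three numbers, yet its nearest neighbour is compound 1 and its furthest is compound 3, and both gaps are within the scatter, so nothing separates the three in this assay.

Compound 4, `CC(C)C[C@H](NC(=O)CN(c1nc(Cl)nc2[nH]cnc12)C1CC1)C(=O)O`, is not yet measured. It differs from compound 2 as follows: isopropyl in place of carboxymethyl on a saturated chain carbon, two bonds along the chain from an amide-type nitrogen and a carbonyl carbon.

One measured step sits at the same place on the chain: a number 0.4 percentage points lower from compound 1 to compound 3 (within the scatter). That exchange, hydrogen in place of (methylsulfanyl)methyl on a saturated chain carbon, two bonds along the chain from an amide-type nitrogen and a carbonyl carbon, left this assay unmoved. For the measured compounds named here, the change from compound 2 to compound 4 is a different group exchange at that place, carboxymethyl leaving and isopropyl entering, and the data hold no step of that kind. Going by the values given here, with the one step at this position within the scatter, the expected step of a number 0.7 percentage points lower from compound 2 to compound 4 (within the scatter) is none beyond the scatter.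

Compound 4 is therefore estimated at 44% in this assay, expected to fall between 30% and 58%.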

Compound 4, a percentage reported as activity, at one dose (the size of the read-out at that dose, not a potency): 27%
The estimate for compound 4 lay 17 percentage points above the measured number; the whole stated range lies above it.
By their numbers in this assay, from the lowest: compound 4; then compounds 3, 1 and 2 (each within the scatter of the next).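

The saturated chain carbon, two bonds along the chain from an amide-type nitrogen and a carbonyl carbon, is not silent in this assay: a number 17.7 percentage points lower from compound 2 to compound 4 (beyond the scatter), whereas a number 0.4 percentage points lower from compound 1 to compound 3 (within the scatter). The position can therefore move the read-out, but only the exchange of carboxymethyl for isopropyl has done so here, and the compounds shown do not support treating every group at this place as interchangeable. The exchange removes the hydrogen-bond donor and the hydrogen-bond acceptor counted for carboxymethyl, yet no measurement on hand ties the step to that difference or to any other feature of the two groups.

The compounds leave open whether the step follows the departure of carboxymethyl or the arrival of isopropyl, a question that a plain methyl group in the same free-acid setting would help to separate. They also leave open how an aminobutyl chain or a primary amide at this place would read, and whether the step from carboxymethyl to isopropyl would be of similar size with the benzyl ester in place of the free carboxylic acid.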